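Removing the Nitro Group from Compound 2

The compounds below may be only part of what the source reports. "The series", "measured", "known", "first", "only" and "open" are said of these compounds alone.

In a functional assay for inhibition, read by spectrophotometry, with a stated time of 20 min, tested at 5 mg/mL (on this read-out higher numbers stand for a stronger effect at the one concentration tested and lower numbers for a weaker effect), the measured compounds gave:
Compound 1 `CC(=O)c1ccc(NC(=O)CN(C(=O)c2ccccc2)S(=O)(=O)c2ccc(C)cc2)cc1`: 18.7%
Compound 2 `CC(=O)c1ccc(NC(=O)CN(C(=O)c2ccccc2)S(=O)(=O)c2ccc([N+](=O)[O-])cc2)cc1`: 20.7%
Compound 3 `CC(=O)c1ccc(NC(=O)C(CC(C)C)N(C(=O)c2ccccc2)S(=O)(=O)c2ccc([N+](=O)[O-])cc2)cc1`: 81.3%

Compound 2 stands second highest of these three numbers. Its nearest neighbour is compound 1, and the step of a number 2 percentage points higher from compound 1 to compound 2 (within the scatter) lies within the scatter; the furthest is compound 3, reached by the step of a number 60.6 percentage points higher from compound 2 to compound 3 (beyond the scatter), which is large and beyond the scatter. Compound 4 `CC(=O)c1ccc(NC(=O)CN(C(=O)c2ccccc2)S(=O)(=O)c2ccccc2)cc1` differs from compound 2 in one place: hydrogen in place of nitro on an aromatic carbon. The step that bears on this change is a number 2 percentage points higher from compound 1 to compound 2 (within the scatter), where nitro replaced methyl on the same aromatic carbon without moving the number beyond the scatter. Because a number 2 percentage points higher from compound 1 to compound 2 (within the scatter) was that small, the expected step of a number 1.7 percentage points lower from compound 2 to compound 4 (within the scatter) is none beyond the scatter. Compound 4 is therefore estimated at 19% in this assay, with a range from 8% to 32%.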

Compound 4, a percentage reported as inhibition, at one concentration (the size of the read-out at that concentration, not a potency): 45.4%
Beside the measured number, compound 4's estimate is 26.4 percentage points below it; the whole stated range lies below it.
By their numbers in this assay, from the lowest: compounds 1 and 2 (each within the scatter of the next); then compound 4; then compound 3.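

At this aromatic carbon the group does matter in this assay: with hydrogen in place of nitro the result is a number 24.7 percentage points higher from compound 2 to compound 4 (beyond the scatter) and with hydrogen in place of methyl it is a number 26.7 percentage points higher from compound 1 to compound 4 (beyond the scatter) even though nitro and methyl had stood within the scatter of each other. The flat step between those two groups therefore did not mean that the position was indifferent. Nothing measured here accounts for this rise. Still open, going by these compounds, is where an amine or a carboxylic acid at this carbon would fall, and whether hydrogen in place of nitro raises the number likewise when the isobutyl group of compound 3 is present.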